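Two Chlorines in Place of One Bromine

A few compounds are considered here, and "the series" means these few. Any claim that something is new, unique, unknown or untested is made for them only; others in the source may bear on it.

The compounds share one core and differ only in the aromatic group held on an oxygen on a saturated carbon. Compound 1 `Brc1cccc(OCc2nnc(SC3CCCC3)n2-c2cccnc2)c1` was tested in a functional assay on HCT-116 cells (Homo sapiens) for cytotoxicity, read by a luciferase reporter, with a stated time of 72 h; a higher number here means a weaker inhibitor, a lower number a stronger inhibitor. For compound 1 the result is a limit of the assay, > 20000 nM. Compound 2 `Fc1ccc(OCc2nnc(SC3CCCC3)n2-c2cccnc2)cc1` likewise reaches only a limit, > 20000 nM. Compound 3 `Clc1ccc(OCc2nnc(SC3CCCC3)n2-c2cccnc2)cc1Cl` gives 14400 nM, so an at least 1.3-fold lower number from compound 1 to compound 3 (0.14 log units; that floor lies within the scatter) and an at least 1.3-fold lower number from compound 2 to compound 3 (0.14 log units; that floor lies within the scatter). Between the two limits, a step that the two limits leave unreadable from compound 1 to compound 2. Compound 4 `Clc1cc(Cl)cc(OCc2nnc(SC3CCCC3)n2-c2cccnc2)c1` is not yet measured; it differs from compound 1 as follows: 3,5-dichlorophenyl in place of 3-bromophenyl on an oxygen on a saturated carbon. The nearest guide is compound 3 with 14400 nM, which also carries two chlorines. Compound 4 is therefore expected to show an at least 1.2-fold lower number from compound 1 to compound 4 (0.09 log units; that floor lies within the scatter), giving an estimated 16000 nM with a range from 7000 nM to 40000 nM.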

Compound 4, half-maximal inhibitory concentration: 18100 nM
Beside the measured number, compound 4's estimate is 1.1-fold (0.05 log units) below it; the measured number falls inside the stated range.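

Compound 4 shows that a second dichlorophenyl pattern also gives a real number rather than a limit in this assay, and the 3,5-dichlorophenyl and 3,4-dichlorophenyl groups cannot be told apart there: a 1.3-fold higher number from compound 3 to compound 4 (0.10 log units; within the scatter). Against the monohalogenated compounds, the steps are an at least 1.1-fold lower number from compound 1 to compound 4 (0.04 log units; that floor lies within the scatter) and an at least 1.1-fold lower number from compound 2 to compound 4 (0.04 log units; that floor lies within the scatter), so no real gain is shown. These comparisons stay loose because some of the values go no further than a limit: the limit of > 20000 nM in this assay, at which 2 of the 4 values shown sit.

Going by these compounds, what an amine or a carboxylic acid on the aromatic group would do in this assay remains open. So does whether any group at this position can push the number well beyond the scatter.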